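Working notes: hydroxy on the outer phenyl of compound 3

The source may report more compounds than this note shows. Statements on the series, on what has been measured and on what is new or still open speak of the compounds shown alone.

Measured in a functional assay on KB cells (Homo sapiens) for inhibition, read by sulforhodamine B assay; on this read-out lower numbers stand for stronger inhibition of growth and higher numbers for weaker inhibition of growth:
Compound 1 `c1ccc(-c2ccc(-c3ccc(-c4nc5ccccc5[nH]4)cc3)cc2)cc1`: 39700 nM
Compound 2 `Cc1ccc2[nH]c(-c3ccc(-c4ccc(-c5cccc(Cl)c5)cc4)cc3)nc2c1`: 2260 nM
Compound 3 `Cc1ccc2[nH]c(-c3ccc(-c4ccc(-c5ccccc5)cc4)cc3)nc2c1`: 32100 nM

Compound 3 sits in the upper part of this short range, within the scatter of compound 1 and well above compound 2. The next structure is compound 4 `Cc1ccc2[nH]c(-c3ccc(-c4ccc(-c5ccc(O)cc5)cc4)cc3)nc2c1`, with hydroxy in place of hydrogen on an aromatic carbon, para to a large group: hydroxy in place of hydrogen on an aromatic carbon. The same difference reads phenyl to 4-hydroxyphenyl.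

For the measured compounds named here, two measured steps touch compound 3. The methyl step, a 1.2-fold lower number from compound 1 to compound 3 (0.09 log units; within the scatter), leaves the changing phenyl untouched and offers little guidance here. Going by the values given here, the chloro step, a 14-fold higher number from compound 2 to compound 3 (1.15 log units; beyond the scatter), does replace a group on that phenyl and is the only direct guide. Read back towards compound 2, a group on that phenyl goes with a lower number. Among the compounds with values here, no measured compound carries hydroxy, however, so the size of the chloro step cannot be carried over whole, and the direction remains uncertain.

A lower number in this assay is therefore expected, by a smaller step than the chloro one. The expected step is a 2.7-fold lower number from compound 3 to compound 4 (0.43 log units; beyond the scatter). For compound 4 the estimated value is 12000 nM, with an expected range of 3500 nM to 35000 nM.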

Compound 4, concentration for 50% growth inhibition: 21200 nM
Compound 4: the middle estimate sits 1.8-fold (0.25 log units) below what was measured; measured number inside the range.
By their numbers in this assay, from the lowest: compound 2; then compounds 4, 3 and 1 (each within the scatter of the next).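

In this assay, hydroxy para to a large group on the outer phenyl stays within the scatter of compound 3, with a 1.5-fold lower number from compound 3 to compound 4 (0.18 log units; within the scatter), so a group on that phenyl does not by itself go with a clearly lower number, which the chloro step alone could not show. The distance to the chloro compound stays beyond the scatter, with a 9.4-fold higher number from compound 2 to compound 4 (0.97 log units; beyond the scatter), so the low number of compound 2 is not shared by both substituted outer phenyls, although this step changes the group and its place together and the two contributions cannot be separated. No measurement at hand offers an explanation for either step.

The compounds shown leave open whether the low number of compound 2 belongs to chloro itself or to where it sits, a question that chloro para to a large group or a 3-hydroxyphenyl compound would address. They also leave open whether an amine, a methoxy group or a carboxylic acid para to a large group would stay within the scatter of compound 3 as hydroxy does.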